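Methyl on the imidazole ring: one step, two scaffolds

A few compounds are considered here, and "the series" means these few. Any claim that something is new, unique, unknown or untested is made for them only; others in the source may bear on it.

Compound 1, `CC1CCC(=O)N1CC#CCn1ccnc1`, and compound 2, `Cc1cncn1CC#CCN1C(=O)CCC1C`, share a core; compound 3, `CC(=O)N(C)CC#CCn1ccnc1`, carries a smaller amide in its place, and the difference between the two cores is not broken down here. In a functional assay on the whole organism for agonist activity, with Mus musculus as the target (a lower number here means that less compound is needed, a higher number that more compound is needed for the effect), compound 1 gives only a limit, > 100 mg/kg. Compound 2 likewise gives only a limit in this assay, > 100 mg/kg. Going by the values given here, compound 3, by contrast, gives 1.4 mg/kg in this assay, the only number among the three, with the limit of > 100 mg/kg in this assay, at which 2 of the 3 values shown sit, being where the other two sit. The change from compound 1 to compound 2, (methyl in place of hydrogen on an aromatic carbon), made a step that the two limits leave unreadable from compound 1 to compound 2.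

Compound 4, `CC(=O)N(C)CC#CCn1cncc1C`, still to be measured, differs from compound 3 by methyl in place of hydrogen on an aromatic carbon; the surroundings are told as the ring atom that bears a group of 9 heavy atoms rather than a large group, so it is the same kind of change. Since compound 3 gives 1.4 mg/kg and the earlier step is unreadable, the expected step is a 2.1-fold higher number from compound 3 to compound 4 (0.33 log units; beyond the scatter), and compound 4 is estimated at 3 mg/kg, between 0.7 mg/kg and 15 mg/kg.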

Compound 4, dose for half-maximal effect: > 100 mg/kg
Compound 4 was reported as a limit (the forecaster's own chance of this, stated with the estimate: 15%); middle value at least 33-fold (1.52 log units) away from the limit.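

On the core of compound 3, methyl in place of hydrogen on an aromatic carbon gives an at least 71-fold higher number from compound 3 to compound 4 (1.85 log units; beyond the scatter) in this assay, so on this core the change means that much more compound is needed for the effect. The same change on the other core cannot be read, as compound 1 and compound 2 each give only a limit, so nothing can be said about whether the step carries from one core to another, whether in agreement or in disagreement. The size of the step is also only a bound and not a measured size, as compound 4 gives only a limit, the same one as two other compounds: the limit of > 100 mg/kg in this assay, at which 3 of the 4 values shown sit.

The compounds shown leave open whether an ethyl or a chlorine atom on that aromatic carbon would give the same result as methyl. They also leave open how compounds with an amine or a longer chain in place of the small amide of compound 3 would read in this assay on this core.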